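A few compounds are considered here, and "the series" means these few. Any claim that something is new, unique, unknown or untested is made for them only; others in the source may bear on it.

The measured compounds and their values in this set:

Compound 1 `Oc1nnc(Br)c2c(Br)nc(Br)n12` gives 27000 nM.
Compound 2 `O=C(CSc1nncc2cncn12)c1ccccc1` gives > 48000 nM, which is a limit of the assay and not a number.
Compound 3 `CCOC(=O)Cn1ncc2c(C)ncn2c1=O` gives > 48000 nM, which is also a limit of the assay and not a number.

All three were tested in a functional assay for inhibition, with Homo sapiens as the target; a lower number here means a stronger inhibitor, a higher number a weaker inhibitor. For the measured compounds named here, compound 1 is the only one with a numerical value in this assay. For compound 3 the assay gives only a limit, so its standing among the three cannot be fixed more closely than that; one further value in the set is a limit as well, and both sit at the limit of > 48000 nM in this assay, at which 2 of the 3 values shown sit. Going by the values given here, no pair of the measured compounds differs in a single place, so no step size has been observed in this set.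

Compound 4 `CCOC(=O)Cn1ncc2cncn2c1=O` is the next compound, not yet measured. It differs from compound 3 by hydrogen in place of methyl on an aromatic carbon. Among the compounds with values here, no measured step is available for comparison. The size of the expected change rests on the change itself, which is small. The step from compound 3 to compound 4 in this assay is expected to be a step that the limit leaves unreadable from compound 3 to compound 4, that is, nothing beyond the usual scatter. Compound 4 is therefore estimated at 60000 nM, with a range from 20000 nM to 200000 nM, and most likely the assay will again report only a limit.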

Compound 4, half-maximal inhibitory concentration: > 48000 nM
Compound 4 was reported as a limit (the forecaster's own chance of this, stated with the estimate: 80%); the middle value does not contradict the limit.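

In this assay, compound 3 and compound 4 are both reported only as limits of the assay, so no step between them can be read: the limit of > 48000 nM in this assay, at which 3 of the 4 values shown sit.

The compounds shown leave open what effect, if any, hydrogen in place of methyl on an aromatic carbon has on inhibition.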